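Adding one more chain to compound 3

This account rests on a few compounds, and the source may have more. Where it says the series, first, only, none or still open, it means among the compounds named here.

In a functional assay on A549 cells (Homo sapiens) for cytotoxicity, read by XTT assay, with a stated time of 72 h (on this read-out lower numbers stand for stronger inhibition and higher numbers for weaker inhibition), compound 1 `CC(C)=CCC/C=C(\C)Cc1c(O)cc(O)c2c(=O)cc(-c3ccccc3)oc12` gives 28000 nM, and compound 2 `C=C1CC[C@H]2C(C)(C)CCC[C@]2(C)[C@H]1CC/C(C)=C/Cc1c(O)cc(O)c2c(=O)c(O)c(-c3ccc(O)cc3)oc12` gives 32000 nM. Compound 3 `CC(C)=CCC/C=C(\C)Cc1c(OC/C=C(\C)CCC=C(C)C)cc(O)c2c(=O)cc(-c3ccccc3)oc12` reads > 100000 nM, which is a limit of the assay and not a number. Compound 4 `CC(C)=CCC/C=C(\C)Cc1c(OC/C=C(\C)CCC=C(C)C)c(C/C=C(\C)CCC=C(C)C)c(O)c2c(=O)cc(-c3ccccc3)oc12` carries 3,7-dimethylocta-2,6-dien-1-yl in place of hydrogen on an aromatic carbon of compound 3 (3,7-dimethylocta-2,6-dien-1-yl in place of hydrogen on an aromatic carbon). For the measured compounds named here, one measured step bears on this: an at least 3.5-fold higher number from compound 1 to compound 3 (0.55 log units; beyond the scatter), where the same group replaced hydrogen on an oxygen on an aromatic ring. A second such group is therefore expected to bring no drop in this assay, and more likely a modest rise. The expected change is a step that the limit leaves unreadable from compound 3 to compound 4. For compound 4 the estimated value is 120000 nM, within an expected range of 40000 nM to 350000 nM.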

Compound 4, half-maximal inhibitory concentration: 29000 nM
For compound 4 the middle estimate is 4.1-fold (0.62 log units) above the measured one; the whole stated range lies above it.
By their numbers in this assay, from the lowest: compounds 1, 4 and 2 (each within the scatter of the next). At a limit, above all of these: compound 3.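

In this assay, 3,7-dimethylocta-2,6-dien-1-yl on this aromatic carbon gives an at least 3.4-fold lower number from compound 3 to compound 4 (0.53 log units; beyond the scatter) and so goes with a lower number. On the oxygen the same group had gone the other way, with an at least 3.5-fold higher number from compound 1 to compound 3 (0.55 log units; beyond the scatter) in the earlier step. Going by these compounds, compound 3 stands at a limit of the assay, so the full size of the new step stays unknown: the limit of > 100000 nM in this assay, at which 1 of the 4 values shown sits.

The compounds shown leave open whether a smaller group on this aromatic carbon, such as methyl, would also lower the number. They also leave open what an amine there would give.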